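The source may report more compounds than this note shows. Statements on the series, on what has been measured and on what is new or still open speak of the compounds shown alone.

Of the compounds shown here, three have so far been measured in a physicochemical assay on cells (Homo sapiens), with a stated time of 18 h, tested at 1 uM; a lower number here means a stronger effect, a higher number a weaker effect of the compound at the concentration tested. Compound 1 `COc1cc(/C=N/NC(=O)c2ccncc2)cc(OC)c1O` gives 48% in this assay. Compound 2 `COc1cc(/C=N/NC(=O)OCc2ccccc2)cc(OC)c1O` gives 38% in this assay, and compound 3 `COc1cc(/C=N/NC(=O)c2ccncc2)cc(OC)c1OC` gives 95% in this assay. Compound 3 therefore stands highest of the three numbers, which means the weakest effect at the concentration tested, and its distance to each of the other two lies beyond the scatter. Two single changes connect these compounds: a number 47 percentage points higher from compound 1 to compound 3 (beyond the scatter), and a number 10 percentage points lower from compound 1 to compound 2 (within the scatter).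

Compound 4 `COc1cc(/C=N/NC(=O)OCc2ccccc2)cc(OC)c1OC` is the next compound to be measured in this assay. It differs from compound 3 in one place: benzyloxy in place of pyridin-4-yl on a carbonyl carbon. Exactly this replacement has already been measured once, in the step of a number 10 percentage points lower from compound 1 to compound 2 (within the scatter), where the number moved only slightly and stayed within the scatter. On that single precedent, the step of a number 7 percentage points lower from compound 3 to compound 4 (within the scatter) is expected to stay within the scatter as well, with at most a slight drift downward, so compound 4 is expected to remain near the top of this small set. The estimate for compound 4 in this assay is 88%, with a likely range from 72% to 100%.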

Compound 4, a percentage reported as activity, at one concentration (the size of the read-out at that concentration, not a potency): 95%
For compound 4 the middle estimate is 7 percentage points below the measured one; measured number inside the range.
By their numbers in this assay, from the lowest: compounds 2 and 1 (each within the scatter of the next); then compounds 3 and 4 (each within the scatter of the next).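

In this assay the replacement of pyridin-4-yl by benzyloxy on a carbonyl carbon gives no change at the digits printed from compound 3 to compound 4 (within the scatter) and so has now been read on two backgrounds, with a hydrogen on the oxygen in the first pair and a methyl on it in the second, and both steps stay within the scatter. The other change, methyl in place of hydrogen on an oxygen on an aromatic ring, gives a number 57 percentage points higher from compound 2 to compound 4 (beyond the scatter) in the benzyloxy pair, which matches in size the step seen in the pyridin-4-yl pair, a number 47 percentage points higher from compound 1 to compound 3 (beyond the scatter), so among these four compounds this large step appears with either group on the carbonyl carbon and no compound goes against it. Nothing available explains why the methyl on that oxygen matters so much while the swap on the carbonyl carbon does not.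

On these data alone, whether an ethyl or a longer chain on that oxygen would behave like the methyl or like the hydrogen remains open. Also open, as far as these compounds go, is whether an amine or a simple alkyl chain on the carbonyl carbon would match pyridin-4-yl and benzyloxy.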